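Swapping Methoxy for Ethyl on an Acid-Bearing Carbon

The compounds below may be only part of what the source reports. "The series", "measured", "known", "first", "only" and "open" are said of these compounds alone.

Of the compounds shown here, three have so far been tested in a functional assay on CHO cells for antagonist activity at sphingosine 1-phosphate receptor 2 (Homo sapiens), read by GTPgammaS binding; on this read-out higher numbers stand for weaker inhibition and lower numbers for stronger inhibition. Compound 1 `COc1cc(OC)c(NC(=O)Cn2nc(CC(=O)O)c3ccccc32)cc1Cl` gives 8980 nM, compound 3 `O=C(O)Cn1nc(CC(=O)Nc2ccc(OC(F)(F)F)c(Cl)c2)c2ccccc2c1=O` gives 754 nM, and compound 2 `COC(C(=O)O)c1nn(Cc2cn3cc(OCC4CC4)c(Cl)cc3n2)c2ccccc2c1=O` gives 58 nM. Compound 2 thus stands lowest of the three numbers, which on this read-out means the strongest blocking of the receptor; its nearest neighbour is compound 3 and the furthest is compound 1, and both of those gaps lie beyond the usual scatter of repeated measurements.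

Compound 4 `CCC(C(=O)O)c1nn(Cc2cn3cc(OCC4CC4)c(Cl)cc3n2)c2ccccc2c1=O` has not yet been measured. It differs from compound 2 in a single place: ethyl in place of methoxy on a saturated chain carbon bound to an aromatic carbon and a carbonyl carbon. The carboxylic acid on that same carbon and the rest of the shared core of compound 2 stay as they were.

Within the data shown here, no pair of measured compounds differing in just one place is available here, so the size of this step cannot be read from earlier data. The exchange keeps the acid and swaps one small group for another of the same size, and the expectation is a step of modest size, if any, most likely toward a somewhat higher number. In this assay compound 4 is expected to give about 90 nM, within a range from 30 nM to 270 nM. The expected step is a 1.6-fold higher number from compound 2 to compound 4 (0.19 log units; within the scatter).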

Compound 4, half-maximal inhibitory concentration: 43 nM
Estimate against measurement, compound 4: 2.1-fold (0.32 log units) above; the measured number falls inside the stated range.
By their numbers in this assay, from the lowest: compounds 4 and 2 (each within the scatter of the next); then compound 3; then compound 1.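

In this assay, among these compounds, this is the first direct comparison at this position: ethyl in place of methoxy on a saturated chain carbon bound to an aromatic carbon and a carbonyl carbon gives a 1.3-fold lower number from compound 2 to compound 4 (0.13 log units; within the scatter) and so leaves the two compounds indistinguishable on this read-out. Among the compounds shown here, both groups have 2 heavy atoms, but methoxy has 1 hydrogen-bond acceptor and ethyl has none, so on this core the oxygen of the methoxy group is not required for a number in this range, whereas the earlier compounds could not show this as they differ from compound 2 in more than one place and no steps to them can be read. Nothing measured here explains why the two groups read alike.

From the compounds shown here alone, with only methoxy and ethyl compared on this carbon, it remains open whether a hydroxyl group, an amine or a longer chain such as propyl would keep the number in this range. Going by these compounds, the carboxylic acid is present on that carbon in both compound 2 and compound 4, so what happens when it is replaced by an amide or a tetrazole also remains open.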